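Benzyl in place of chloropyridyl on the piperazine nitrogen

The source may hold more compounds than are shown below. What is called first, only, known or untested is meant among the compounds shown, and "the series" means these compounds.

The series shares one core and differs in the group on an amine nitrogen in a ring. Compound 1 `Cc1cccc(N2CCN(c3nc(C(F)(F)F)ccc3CNC(=O)C(C)c3ccc(NS(C)(=O)=O)c(F)c3)CC2)c1` gives 39.2 nM in a functional assay on CHO-K1 cells for antagonist activity at transient receptor potential cation channel subfamily V member 1 (Homo sapiens), read by FLIPR; on this read-out lower numbers stand for stronger inhibition and higher numbers for weaker inhibition. Compound 2 `COc1ccc(N2CCN(c3nc(C(F)(F)F)ccc3CNC(=O)C(C)c3ccc(NS(C)(=O)=O)c(F)c3)CC2)cc1` gives 44.5 nM in this assay, and the step of a 1.1-fold higher number from compound 1 to compound 2 (0.06 log units; within the scatter) is not a change that can be read. Compound 3 `CC(C(=O)NCc1ccc(C(F)(F)F)nc1N1CCN(c2ncccc2Cl)CC1)c1ccc(NS(C)(=O)=O)c(F)c1` gives 117 nM in this assay, the highest of the three numbers; its distance from compound 2 is a 2.6-fold higher number from compound 2 to compound 3 (0.42 log units; beyond the scatter) and from compound 1 it is a 3.0-fold higher number from compound 1 to compound 3 (0.47 log units; beyond the scatter).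

Compound 4 `CC(C(=O)NCc1ccc(C(F)(F)F)nc1N1CCN(Cc2ccccc2)CC1)c1ccc(NS(C)(=O)=O)c(F)c1` is not yet measured. The change from compound 3 is benzyl in place of 3-chloropyridin-2-yl on an amine nitrogen in a ring. Within the data shown here, two measured steps bear on this place: both moves onto 3-chloropyridin-2-yl, from compound 1 and from compound 2, raised the number by a modest amount, so leaving that group again would be expected to lower it. Among the measured compounds shown here, no measured compound carries a benzyl here, and none shows what the added methylene or the lost acceptor does, so the expectation stays loose.

For compound 4 a modest step downward is expected, a 1.8-fold lower number from compound 3 to compound 4 (0.26 log units; within the scatter), giving an estimated 65 nM with a range from 25 nM to 180 nM.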

Compound 4, half-maximal inhibitory concentration: 634 nM
Beside the measured number, compound 4's estimate is 9.8-fold (0.99 log units) below it; the whole stated range lies below it.
By their numbers in this assay, from the lowest: compounds 1 and 2 (each within the scatter of the next); then compound 3; then compound 4.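

In this assay the benzyl group gives the first clear loss at this ring nitrogen, and a 5.4-fold higher number from compound 3 to compound 4 (0.73 log units; beyond the scatter) shows that moving away from 3-chloropyridin-2-yl does not by itself return the number towards those of compound 1 and compound 2. Among these compounds, the gaps to those two compounds are wider, with a 14-fold higher number from compound 2 to compound 4 (1.15 log units; beyond the scatter) and a 16-fold higher number from compound 1 to compound 4 (1.21 log units; beyond the scatter) placing compound 4 beyond the scatter of every other compound, so the three compounds with an aromatic ring directly on the amine nitrogen all give lower numbers than the one compound with a methylene link, and none of the four goes against this. No measurement in hand gives a reason for this change.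

A pyridin-2-ylmethyl group on the same nitrogen would show whether the higher number goes with the methylene link or with the carbon-only ring, while a benzoyl group would test the link with a carbonyl in place of the methylene. Also open, from the compounds shown here alone, is whether a longer chain, such as 2-phenylethyl, moves the number further in the same direction.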